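This account rests on a few compounds, and the source may have more. Where it says the series, first, only, none or still open, it means among the compounds named here.

Compound 1 `COc1ccc(C(OCc2ccccc2)c2cccc3ccccc23)c(OC)c1OC` is the starting point. In a functional assay on THP-1 cells (Homo sapiens) for inhibition, read by sulforhodamine B assay, with a stated time of 48 h (a higher number here means a weaker inhibitor, a lower number a stronger inhibitor), compound 1 gives > 20000 nM, which is a limit of the assay rather than a measured number. Compound 2 `COc1ccc(C(c2ccccc2O)c2cccc3ccccc23)c(OC)c1OC` likewise gives only a limit, > 20000 nM, in this assay. Compound 3 `COc1ccc(C(c2ccc(O)cc2)c2cccc3ccccc23)c(OC)c1OC` does yield a number: in this assay compound 3 gives 9450 nM. The step that the two limits leave unreadable from compound 1 to compound 2 cannot be sized because of the limit of > 20000 nM in this assay, at which 2 of the 3 values shown sit. The step of an at least 2.1-fold lower number from compound 1 to compound 3 (0.32 log units; beyond the scatter) is at least modest, and so is an at least 2.1-fold lower number from compound 2 to compound 3 (0.32 log units; beyond the scatter).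

Compound 4 `COC(=O)c1ccc(COC(c2ccc(OC)c(OC)c2OC)c2cccc3ccccc23)cc1` keeps the benzyloxy group of compound 1 and differs from it only by methoxycarbonyl in place of hydrogen on an aromatic carbon. Going by the values given here, none of the measured steps touches this part of the molecule: each of them exchanges the whole benzyloxy group for a hydroxyphenyl, so none bears directly on decorating the benzyl ring. With compound 1 itself sitting at a limit, there is no basis for expecting a move beyond the scatter in either direction. The expected step in this assay is therefore a step that the limit leaves unreadable from compound 1 to compound 4, essentially none beyond the scatter. Compound 4 is accordingly estimated at 25000 nM, with a range from 8000 nM to 80000 nM, and a limit rather than a number is the more likely outcome.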

Compound 4, half-maximal inhibitory concentration: > 20000 nM
Compound 4 ended at the assay's limit; the forecaster's own chance of this, stated with the estimate: 60%; the middle value is on the limit's open side.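

In this assay compound 4 gives > 20000 nM, a limit of the assay and not a number. Compound 1 also stands at a limit, so no step can be read between compound 1 and compound 4: the limit of > 20000 nM in this assay, at which 3 of the 4 values shown sit.

The compounds shown leave open whether 4-(methoxycarbonyl)benzyl in place of benzyl changes inhibition at all.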